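Trifluoromethyl removal on the urea aryl ring

The source may hold more compounds than are shown below. What is called first, only, known or untested is meant among the compounds shown, and "the series" means these compounds.

Measured in a functional assay on NCI/ADR-RES cells (Homo sapiens) for inhibition, read by sulforhodamine B assay, with a stated time of 48 h; a lower number here means a stronger inhibitor of growth, a higher number a weaker inhibitor of growth:
compound 1 `COc1cc(-c2nn(-c3cccc(NC(=O)Nc4cc(C(F)(F)F)cc(C(F)(F)F)c4)c3)cc2-c2ccncc2)ccc1Cl` gives 1010 nM
compound 2 `O=C(Nc1cccc(-n2cc(-c3ccncc3)c(-c3ccc(Cl)c(O)c3)n2)c1)Nc1ccc(Cl)c(Cl)c1` gives 2740 nM

Compound 1 has the lowest of the two numbers in this assay; compound 2 lies beyond the scatter from it, at a higher number. The two structures differ in several places at once, so no single change can be read from that pair.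

Compound 3 `COc1cc(-c2nn(-c3cccc(NC(=O)Nc4cccc(C(F)(F)F)c4)c3)cc2-c2ccncc2)ccc1Cl` is yet to be measured. It differs from compound 1 in one place: hydrogen in place of trifluoromethyl on an aromatic carbon, meta to a trifluoromethyl group. Going by the values given here, no measured pair isolates this change, so the step from compound 1 to compound 3 in this assay is expected only as a modest move to a higher number, perhaps not clearly beyond the scatter, namely a 2.0-fold higher number from compound 1 to compound 3 (0.30 log units; within the scatter). For compound 3 the estimate in this assay is 2000 nM, with a plausible range from 700 nM to 6000 nM.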

Compound 3, concentration for 50% growth inhibition: 783 nM
Estimate against measurement, compound 3: 2.6-fold (0.41 log units) above, within the range that was stated.
By their numbers in this assay, from the lowest: compounds 3 and 1 (each within the scatter of the next); then compound 2.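

In this assay hydrogen in place of trifluoromethyl on an aromatic carbon, meta to a trifluoromethyl group, gives a 1.3-fold lower number from compound 1 to compound 3 (0.11 log units; within the scatter) and so leaves the two compounds level. Going by these compounds alone, this is the first reading of a single change: with the other trifluoromethyl group kept, this position takes hydrogen in place of a group of 4 heavy atoms with no difference that this read-out can resolve. No measurement at hand accounts for this flat step.

Open, from the compounds shown here alone, is whether this carbon tolerates other groups, such as a nitrile, an amine or a carboxylic acid, as it tolerates hydrogen. Also open is what hydrogen in place of the remaining trifluoromethyl group would give, since the compounds shown keep that group whenever this position changes alone.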